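Pyrazoline antiproliferatives: moving from compound 3 to compound 4

The compounds below may be only part of what the source reports. "The series", "measured", "known", "first", "only" and "open" are said of these compounds alone.

Compound 1 `Clc1ccc(C2CC(c3ccc4c(c3)OCCO4)=NN2c2ccccc2)cc1`: 38600 nM
Compound 2 `Clc1cccc(C2CC(c3ccc4c(c3)OCCO4)=NN2c2ccccc2)c1`: 1750 nM
Compound 3 `CSc1ccc(C2CC(c3ccc4c(c3)OCCO4)=NN2c2ccccc2)cc1`: 6870 nM

In a functional assay on WM 266-4 cells (Homo sapiens) for antiproliferative activity, read by MTT assay, with a stated time of 24 h (on this read-out higher numbers stand for weaker inhibition of growth and lower numbers for stronger inhibition of growth), compound 3 gives 6870 nM, the second highest of the three numbers; compound 2 sits nearer, compound 1 further away. Compound 4 `Fc1ccccc1C1CC(c2ccc3c(c2)OCCO3)=NN1c1ccccc1` carries 2-fluorophenyl in place of 4-(methylsulfanyl)phenyl on a saturated ring carbon. Among the compounds with values here, no measured step puts a 2-fluorophenyl at this position, so the outcome is open. Within the data shown here, the steps that bear on it are a 22-fold lower number from compound 1 to compound 2 (1.34 log units; beyond the scatter), a 5.6-fold lower number from compound 1 to compound 3 (0.75 log units; beyond the scatter) and a 3.9-fold higher number from compound 2 to compound 3 (0.59 log units; beyond the scatter), which show that changing the group on this saturated ring carbon can shift the number by a large or a modest amount in either direction. Compound 4 is therefore expected to stay near compound 3, as a 1.4-fold lower number from compound 3 to compound 4 (0.14 log units; within the scatter), with wide uncertainty. Compound 4 is estimated at 5000 nM, in the range 1000 nM to 25000 nM.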

Compound 4, concentration for 50% growth inhibition: 9120 nM
Compound 4: the middle estimate sits 1.8-fold (0.26 log units) below what was measured, and the stated range covers the measured number.
By their numbers in this assay, from the lowest: compound 2; then compounds 3 and 4 (each within the scatter of the next); then compound 1.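

In this assay, 2-fluorophenyl in place of 4-(methylsulfanyl)phenyl on the saturated ring carbon stays within the scatter, with a 1.3-fold higher number from compound 3 to compound 4 (0.12 log units; within the scatter). The 2-fluorophenyl compound lies between the two chlorophenyl compounds, with a 5.2-fold higher number from compound 2 to compound 4 (0.72 log units; beyond the scatter) and a 4.2-fold lower number from compound 1 to compound 4 (0.63 log units; beyond the scatter), so this position tolerates a group that matches neither chlorophenyl result. Nothing available here explains these numbers. As far as these compounds go, whether an amine or a carboxylic acid on the phenyl ring at this carbon would give a lower number than compound 2 remains open.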